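The source may hold more compounds than are shown below. What is called first, only, known or untested is meant among the compounds shown, and "the series" means these compounds.

Within the data shown here, in a functional assay on DU-145 cells (Homo sapiens) for inhibition, read by MTT assay, with stated times of 18 h and 4 h (a lower number here means a stronger inhibitor, a higher number a weaker inhibitor), compound 1 `CCCCCCCCCCCCCCCCOP(=O)(O)OCCSC(=S)N1CCN(C)CC1` gives 49300 nM as its reading, the only number so far. Compound 2 `CCCCCCOP(=O)(O)OCCSC(=S)N1CCCCC1` records > 100000 nM as a limit of the assay and not a number. With the limit of > 100000 nM in this assay, at which 1 of the 2 values shown sits, as its only position, compound 2 has no exact value to start from. The move to compound 3 `CCCCCCOP(=O)(O)OCCSC(=S)N1CCN(C)CC1` places 4-methylpiperazin-1-yl in place of piperidin-1-yl on a thiocarbonyl carbon, counted as 4-methylpiperazin-1-yl in place of piperidin-1-yl on a thiocarbonyl carbon and nothing more. Among the measured compounds shown here, no measured pair isolates this change. Compound 1 also carries 4-methylpiperazin-1-yl and reaches only 49300 nM in this assay here, so strong inhibition is not expected from this group. The estimated step of a number no higher from compound 2 to compound 3 (the limit leaves the size open) is expected to stay within the scatter, with no clear direction. Compound 3 is expected at 100000 nM with an estimated range from 45000 nM to 200000 nM in this read-out.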

Compound 3, half-maximal inhibitory concentration: > 100000 nM
Compound 3: no number, only a limit (the forecaster's own chance of this, stated with the estimate: 65%); the middle value lies on the limit itself.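

In this assay, placing 4-methylpiperazin-1-yl on the thiocarbonyl carbon in compound 3 does not bring the reading down to a number, so this group alone gives no measurable inhibition on the shorter chain. Among these compounds, the step between compound 2 and compound 3 cannot be read, and neither compound gives more than a limit of the assay: the limit of > 100000 nM in this assay, at which 2 of the 3 values shown sit. With 4-methylpiperazin-1-yl held fixed, hydrogen in place of decyl on the chain gives an at least 2.0-fold higher number from compound 1 to compound 3 (0.30 log units; that floor lies within the scatter), which ties the one exact reading to the longer chain only weakly.

The compounds shown leave open whether piperidin-1-yl and 4-methylpiperazin-1-yl differ at all when carried on the chain of compound 1. They also leave open how an open-chain amine or a carboxylic acid on the thiocarbonyl carbon would read.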